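Replacing methoxy with hydroxymethyl on a carbonyl carbon

A few compounds are considered here, and "the series" means these few. Any claim that something is new, unique, unknown or untested is made for them only; others in the source may bear on it.

Measured in a functional assay on HCT-15 cells (Homo sapiens); a lower number here means that less compound is needed, a higher number that more compound is needed for the effect:
- compound 1 `CCCCNC(=O)c1c(OC)cc(C2OC(c3ccc(N)c(C)c3)=NN2C(C)=O)cc1OC`: 178 uM
- compound 2 `COc1cc(C2OC(c3ccc(N(C)C)cc3)=NN2C=O)cc(OC)c1OC`: 0.096 uM
- compound 3 `COC(=O)N1N=C(c2ccc(N(C)C)cc2)OC1c1cc(OC)c(OC)c(OC)c1`: 40 uM

Among these three numbers, compound 3 holds the second highest, with compound 1 higher and compound 2 far lower. The next structure is compound 4 `COc1cc(C2OC(c3ccc(N(C)C)cc3)=NN2C(=O)CO)cc(OC)c1OC`, which carries hydroxymethyl in place of methoxy on a carbonyl carbon.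

Among the measured compounds shown here, only one measured step bears on this change: a 420-fold higher number from compound 2 to compound 3 (2.62 log units; beyond the scatter). It is large and lies beyond the scatter, and it came with methoxy in place of hydrogen on a carbonyl carbon. For the measured compounds named here, compound 1 differs from the others in more than one place, so it offers no comparable step. Going by the values given here, no measured compound carries hydroxymethyl at this place, so the data cannot say how far the number will move. Compound 4 loses the methoxy that marks the high side of that step, so a sizeable move towards a lower number is expected in this assay, probably only part of the way to compound 2 at 0.096 uM. The expected change is a 20-fold lower number from compound 3 to compound 4 (1.30 log units; beyond the scatter). For compound 4 the estimated value is 2 uM, with an expected range from 0.1 uM to 40 uM.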

Compound 4, concentration for half-maximal effect: 0.026 uM
The estimate for compound 4 lay 77-fold (1.89 log units) above the measured number; measured number below the stated range.
By their numbers in this assay, from the lowest: compound 4; then compound 2; then compound 3; then compound 1.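

In this assay, the same two heavy atoms on a carbonyl carbon whose other neighbour is an amide-type nitrogen in a ring gave very different results when joined differently: hydroxymethyl in place of methoxy produced a 1500-fold lower number from compound 3 to compound 4 (3.19 log units; beyond the scatter). The earlier compounds shown here showed only that methoxy in this place stood far above hydrogen, whereas hydroxymethyl in place of hydrogen gave a 3.7-fold lower number from compound 2 to compound 4 (0.57 log units; beyond the scatter), so a group larger than hydrogen can also go with a lower number, and the count of heavy atoms alone does not set the value. Nothing available explains the size of either step, and the hydrogen-bond donor counted on hydroxymethyl remains only a structural difference between these groups.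

The compounds shown leave open whether the hydroxyl itself matters or whether any group joined through carbon in place of oxygen on this carbonyl would serve, a question that methyl, methoxymethyl or aminomethyl on the core of compound 4 would address. They also leave open how a longer chain, such as 2-hydroxyethyl, would fare in this place.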